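The source may report more compounds than this note shows. Statements on the series, on what has been measured and on what is new or still open speak of the compounds shown alone.

The series varies the group on an amine nitrogen of a shared core. In a functional assay on HeLa cells (Homo sapiens) for inhibition, read by sulforhodamine B assay (on this read-out higher numbers stand for weaker inhibition and lower numbers for stronger inhibition), compound 3 `COc1ccccc1NC1=CC(=O)c2nc3n(c2C1=O)[C@H]1OC[C@@H](O)[C@H]1OC3` gives 2950 nM, and compound 2 `CCc1ccc(NC2=CC(=O)c3nc4n(c3C2=O)[C@H]2OC[C@@H](O)[C@H]2OC4)cc1` gives 3990 nM. These two values cannot be separated: a 1.4-fold lower number from compound 2 to compound 3 (0.13 log units; within the scatter). Compound 1 `O=C1C=C(NCc2ccccc2)C(=O)c2c1nc1n2[C@H]2OC[C@@H](O)[C@H]2OC1` returns only a limit, > 8000 nM. Against that limit, the measured steps are an at least 2.0-fold lower number from compound 1 to compound 2 (0.30 log units; that floor lies within the scatter) and an at least 2.7-fold lower number from compound 1 to compound 3 (0.43 log units; beyond the scatter).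

The next compound, compound 4 `CCOc1ccc(NC2=CC(=O)c3nc4n(c3C2=O)[C@H]2OC[C@@H](O)[C@H]2OC4)cc1`, carries 4-ethoxyphenyl in place of 2-methoxyphenyl on an amine nitrogen. This places 4-ethoxyphenyl in place of 2-methoxyphenyl on an amine nitrogen. The step that bears most directly on this change is the exchange of 4-ethylphenyl for 2-methoxyphenyl at the same place, which stayed within the scatter at a 1.4-fold lower number from compound 2 to compound 3 (0.13 log units; within the scatter). Only the two steps away from benzyl offer any sign of a larger change, and just one of them clears the scatter. No step beyond the scatter, in either direction, is therefore expected in this assay. The expected step is a 1.1-fold higher number from compound 3 to compound 4 (0.05 log units; within the scatter). For compound 4 the estimated value is 3300 nM, with an expected range from 1500 nM to 7000 nM.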

Compound 4, half-maximal inhibitory concentration: 3110 nM
For compound 4 the middle estimate is 1.1-fold (0.03 log units) above the measured one, within the range that was stated.
By their numbers in this assay, from the lowest: compounds 3, 4 and 2 (each within the scatter of the next). At a limit, above all of these: compound 1.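

In this assay, 4-ethoxyphenyl on the amine nitrogen cannot be separated from either aryl group already in the series: a 1.1-fold higher number from compound 3 to compound 4 (0.02 log units; within the scatter), and a 1.3-fold lower number from compound 2 to compound 4 (0.11 log units; within the scatter), the latter also showing that ethoxy in place of ethyl on an aromatic carbon leaves the number within the scatter. A second aryl group now clears the scatter against benzyl, an at least 2.5-fold lower number from compound 1 to compound 4 (0.41 log units; beyond the scatter), alongside compound 3, while compound 2 remains the exception, with its floor within the scatter. The value of compound 1 is a limit, so these steps are floors only: the limit of > 8000 nM in this assay, at which 1 of the 4 values shown sits.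

The compounds shown leave open whether an amine or a carboxylic acid on the phenyl ring, or an alkoxy chain longer than ethoxy, would move the number beyond the scatter. Within the data shown here, also open is whether the place of an alkoxy group on the ring matters, as no pair here holds the same alkoxy group at two places.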